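This account rests on a few compounds, and the source may have more. Where it says the series, first, only, none or still open, it means among the compounds named here.

Measured compounds:
Compound 1 `CC(=O)OC(C)n1cnc2c(Cl)nc(I)nc21` gives 6310 nM in a functional assay on HEp-2 cells (Homo sapiens) for inhibition; on this read-out lower numbers stand for stronger inhibition and higher numbers for weaker inhibition.
Compound 2 `CC(O)n1cnc2c(N)nc(I)nc21` gives > 500000 nM in this assay, which is a limit of the assay and not a number.
Compound 3 `Nc1nc(I)nc2c1ncn2OCCO` gives > 500000 nM in this assay, again a limit of the assay and not a number.

Compound 3 therefore stands at the limit, as does compound 2 (the limit of > 500000 nM in this assay, at which 2 of the 3 values shown sit); only compound 1 carries a numerical value in this assay. For the measured compounds named here, the one step with a single change, a step that the two limits leave unreadable from compound 2 to compound 3, cannot be read.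

Compound 4 `COc1nc(I)nc2c1ncn2OCCO` is not yet measured. It differs from compound 3 by methoxy in place of amino on an aromatic carbon. Going by the values given here, no measured step touches this position: compound 1 carries a chloro group there but also a different substituent on the aromatic nitrogen, so its value says nothing direct about the change from compound 3 to compound 4. With both neighbouring amino compounds at the limit, no direction can be read for this assay.

Compound 4 is expected at 300000 nM, within 30000 nM to 1000000 nM, the expected step being an at least 1.6-fold lower number from compound 3 to compound 4 (0.22 log units; that floor lies within the scatter).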

Compound 4, half-maximal inhibitory concentration: > 500000 nM
Compound 4: no number, only a limit; the forecaster's own chance of this, stated with the estimate: 55%; middle value at least 1.6-fold (0.22 log units) away from the limit.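

Compound 3 and compound 4 both stand at a limit of the assay and not at a number in this assay, so no step between them can be read: the limit of > 500000 nM in this assay, at which 3 of the 4 values shown sit.

Left open is whether methoxy in place of amino on this aromatic carbon changes inhibition at all in this assay.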